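The source may hold more compounds than are shown below. What is called first, only, known or untested is meant among the compounds shown, and "the series" means these compounds.

Compound 1 `O=C(O)CCc1ccc(NCc2ccccc2)cc1` gives 89%.
Compound 2 `O=C(O)CCc1ccc(NCc2ccc(-c3ccccc3)cc2)cc1` gives 92%.

In a functional assay on 1321-N1 cells for agonist activity at Free fatty acid receptor 1 (Homo sapiens), read by calcium flux (a higher number here means a larger maximal response, a lower number a smaller maximal response), compound 1 gives 89%. Among the measured compounds shown here, its only neighbour among the measured compounds is compound 2, and the change from compound 1 to compound 2 produced a number 3 percentage points higher from compound 1 to compound 2 (within the scatter), so the two compounds stand together in this assay with nothing between them that exceeds the scatter.

Compound 3 `COc1ccccc1-c1cccc(CNc2ccc(CCC(=O)O)cc2)c1` has not yet been measured. It differs from compound 1 by 2-methoxyphenyl in place of hydrogen on an aromatic carbon. For the measured compounds named here, the one measured step that bears on this change is the one from compound 1 to compound 2, where a phenyl in place of hydrogen on an aromatic carbon gave a number 3 percentage points higher from compound 1 to compound 2 (within the scatter). Since that step stayed within the scatter, no step beyond the scatter is expected for compound 3 either, and the number for compound 3 is estimated at 90%, between 78% and 100%. This estimate means a step of a number 1 percentage points higher from compound 1 to compound 3 (within the scatter) is expected.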

Compound 3, largest response reached (reported as efficacy), in percent of the reference or control that the assay uses: 109%
For compound 3 the middle estimate is 19 percentage points below the measured one; measured number outside the range, above it.
By their numbers in this assay, from the lowest: compounds 1 and 2 (each within the scatter of the next); then compound 3.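

In this assay, among the compounds shown here, a 2-methoxyphenyl on an aromatic carbon meta to a large group gave a number 20 percentage points higher from compound 1 to compound 3 (beyond the scatter), the only step here that lies beyond the scatter. The earlier step, a number 3 percentage points higher from compound 1 to compound 2 (within the scatter), carried a phenyl on a different carbon of the same ring and stayed within the scatter, so adding an aromatic ring to this part of the core does not always leave the maximal response unchanged. No available evidence accounts for the rise.

Compound 3 differs from compound 2 in both the attachment carbon and the methoxy group, so the shown compounds cannot separate these two contributions. Going by these compounds, it also remains open whether a hydroxyl group or a fluorine atom in place of the methoxy group would keep the response of compound 3.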